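A few compounds are considered here, and "the series" means these few. Any claim that something is new, unique, unknown or untested is made for them only; others in the source may bear on it.

Measured compounds:
- compound 1, `CSCc1cc(C(C)=O)c(O)cc1OCCCCCCC#N`, gives 64%
- compound 2, `CC(=O)c1cc(CO)c(OCCCCCCC#N)cc1O`, gives 8%
- compound 3, `C=CCc1cc(C(C)=O)c(O)cc1OCCCC#N`, gives 6%

All three were tested in an assay on isolated protein for binding affinity to leukotriene B4 receptor 1 (Homo sapiens), tested at 1 uM; a higher number here means more inhibition at the concentration tested (going by the name of the read-out), a lower number less inhibition. Among them compound 3 stands lowest of the three numbers; its nearest neighbour is compound 2, which lies within the usual scatter of it, while compound 1 lies far above it, well beyond the scatter. Compound 4, `C=CCc1cc(C(C)=O)c(O)cc1OCCCCCCC#N`, has not yet been measured in this assay. It differs from compound 3 in one place: 3-cyanopropyl in place of cyano on a saturated chain carbon, three bonds along the chain from an oxygen on an aromatic ring.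

Within the data shown here, only one measured step is available, and it concerns a different part of the shared core: a number 56 percentage points lower from compound 1 to compound 2 (beyond the scatter). Among the measured compounds shown here, that step says nothing about lengthening the chain that carries the nitrile, so no measured step bears directly on the change from compound 3 to compound 4. What the numbers do show is that the two compounds carrying the longer chain, compound 1 and compound 2, span almost the whole range, so the chain length alone does not decide the outcome. The expectation for the step is therefore a modest rise with wide uncertainty, written as a number 14 percentage points higher from compound 3 to compound 4 (beyond the scatter). Compound 4 is estimated to give 20%, expected to fall between 3% and 50%.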

Compound 4, a percentage reported as inhibition, at one concentration (the size of the read-out at that concentration, not a potency): 63%
Estimate against measurement, compound 4: 43 percentage points below, outside the stated range (above it).
By their numbers in this assay, from the lowest: compounds 3 and 2 (each within the scatter of the next); then compounds 4 and 1 (each within the scatter of the next).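

In this assay, 3-cyanopropyl in place of cyano gives a number 57 percentage points higher from compound 3 to compound 4 (beyond the scatter), so with the rest of the molecule unchanged, this part of the chain carrying the nitrile has a large effect on the read-out. The longer chain does not settle the result by itself, since compound 2 carries it too: vinyl in place of hydroxy on a saturated chain carbon bound to an aromatic carbon gives a number 55 percentage points higher from compound 2 to compound 4 (beyond the scatter), while vinyl in place of methylsulfanyl at that same place gives a number 1 percentage points lower from compound 1 to compound 4 (within the scatter), so on the longer chain two of the three groups at that place give similar numbers and hydroxy stands apart. Nothing available explains why either change has the effect it does.

With only these two chain lengths, the compounds shown leave open whether the number climbs steadily with each added carbon or jumps at one particular length, and what a still longer chain would give. They also leave open whether the nitrile itself matters, which a carboxylic acid or an amine in its place on the longer chain would test.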